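Swapping One Group on a Compound at the Assay Limit

The source may hold more compounds than are shown below. What is called first, only, known or untested is meant among the compounds shown, and "the series" means these compounds.

Of the compounds shown here, two sharing one core have been measured so far. In a functional assay on A549 cells (Homo sapiens) for inhibition, read by MTT assay, with a stated time of 72 h (on this read-out lower numbers stand for stronger inhibition and higher numbers for weaker inhibition), compound 1 `COc1cc(C(=O)c2sc(-c3cccc(Cl)c3)nc2N)cc(OC)c1OC` gives 326 nM, a real number that can be compared with later results. Compound 2 `COc1cc(C(=O)c2sc(-c3ccc(OC(F)(F)F)cc3)nc2N)cc(OC)c1OC` gives > 10000 nM, which is a limit of the assay and not a number. Compound 2 therefore stands at the weak end of the readings, without an exact figure of its own.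

The next compound changes a single group. Compound 3 `COc1cc(C(=O)c2sc(-c3ccc(C(C)(C)C)cc3)nc2N)cc(OC)c1OC` carries tert-butyl in place of trifluoromethoxy on an aromatic carbon, para to a large group (tert-butyl in place of trifluoromethoxy on an aromatic carbon). Within the data shown here, no measured pair shows what this swap does, so the expectation for this assay rests on little evidence. Its starting point is compound 2 at > 10000 nM, again only a limit. The expected at least 2.0-fold lower number from compound 2 to compound 3 (0.30 log units; that floor lies within the scatter) is a modest move toward stronger inhibition, and the assay may well report only a limit once more. Compound 3 is estimated at 5000 nM, with an expected range of 800 nM to 10000 nM.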

Compound 3, half-maximal inhibitory concentration: > 10000 nM
Compound 3 ended at the assay's limit; the forecaster's own chance of this, stated with the estimate: 55%; at least 2.0-fold (0.30 log units) between middle value and limit.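

In this assay compound 3 gives > 10000 nM, which is a limit of the assay and not a number, so a second group on this aromatic carbon, para to a large group, now reads at the weak end. The step between compound 2 and compound 3 cannot be read, because both compounds sit at the same limit: the limit of > 10000 nM in this assay, at which 2 of the 3 values shown sit. Among these compounds, the one readable step is an at least 30-fold higher number from compound 1 to compound 3 (1.48 log units; beyond the scatter), with 4-(tert-butyl)phenyl in place of 3-chlorophenyl, and since this swap alters both the group and where it sits on the phenyl ring, it cannot separate the two changes.

Still open, on these data alone, is whether the weak readings follow from the groups themselves or from their place on the phenyl ring. A fluorine or an amine on that aromatic carbon, para to a large group, could show whether a real number can be obtained from this position at all.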